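Dimethylamino in Place of Phenoxy: Cytotoxicity Outlook

The source may hold more compounds than are shown below. What is called first, only, known or untested is meant among the compounds shown, and "the series" means these compounds.

Compound 1 `CCOC(=O)c1c(-c2cccc(C)c2)[nH]c2cc(OC)ccc2c1=O`: in an ADME assay on HepG2 cells (Homo sapiens) for cytotoxicity, read by luminescence, with a stated time of 72 h (on this read-out lower numbers stand for an effect already at smaller amounts and higher numbers for an effect only at larger amounts of compound), compound 1 gives > 21500 nM, a limit of the assay.
Compound 2 `CCOC(=O)c1c(-c2cccc(-c3ccccc3)c2)[nH]c2cc(OC)ccc2c1=O`: in this assay compound 2 gives > 21500 nM, a limit of the assay.
Compound 3 `CCOC(=O)c1c(-c2cccc(Oc3ccccc3)c2)[nH]c2cc(OC)ccc2c1=O`: in this assay compound 3 gives > 21500 nM, a limit of the assay.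

Compound 3 stands at a limit in this assay, and it shares that position with both other compounds, as the limit of > 21500 nM in this assay, at which 3 of the 3 values shown sit, shows. The three steps among the measured compounds, a step that the two limits leave unreadable from compound 1 to compound 2, a step that the two limits leave unreadable from compound 1 to compound 3 and a step that the two limits leave unreadable from compound 2 to compound 3, therefore give no readable size, and none of them can be used to gauge a new change.

Compound 4 `CCOC(=O)c1c(-c2cccc(N(C)C)c2)[nH]c2cc(OC)ccc2c1=O` is the next compound. Its change from compound 3 is dimethylamino in place of phenoxy on an aromatic carbon. For the measured compounds named here, no measured step bears readably on this change, so the expectation for compound 4 rests on the fact that every measured compound sits at the same limit in this assay. The step that the limit leaves unreadable from compound 3 to compound 4 is expected to stay within the scatter. Compound 4 is estimated at 25000 nM in this assay, with a range from 12000 nM to 60000 nM, most likely reported again as a limit.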

Compound 4, half-maximal effective concentration: > 21500 nM
Compound 4: no number, only a limit; the forecaster's own chance of this, stated with the estimate: 80%; the middle value is on the limit's open side.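

In this assay compound 4 gives > 21500 nM, a limit of the assay. For the compounds shown here, no step from compound 1, compound 2 or compound 3 to compound 4 can be read. The compounds shown leave open at what concentration any of the four would show a half-maximal effect, and whether their groups would then differ.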